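Carbamate to cyclopentylmethyl amide on the shared core

The compounds below may be only part of what the source reports. "The series", "measured", "known", "first", "only" and "open" are said of these compounds alone.

Measured compounds:
compound 1 `CCCCOC(=O)Nc1ccc2ccn(Cc3ccc(C(=O)O)cc3OC)c2c1` gives 155 nM
compound 2 `COc1cc(C(=O)NS(=O)(=O)c2ccccc2C)ccc1Cn1cc(CC(C)C(=O)N(C)C)c2ccc(C(=O)NCC3CCCC3)cc21` gives 0.65 nM
compound 3 `CCCCOC(=O)Nc1ccc2c(Cl)cn(Cc3ccc(C(=O)O)cc3OC)c2c1` gives 92.7 nM

In a functional assay on trachea for agonist activity at cysteinyl leukotriene receptor (Homo sapiens) (a lower number here means a stronger inhibitor, a higher number a weaker inhibitor), compound 1 gives the highest of the three numbers. The nearest number is reached by the step of a 1.7-fold lower number from compound 1 to compound 3 (0.22 log units; within the scatter). Among the compounds with values here, compound 2 is furthest; its value set against that of compound 1 shows a gap well beyond the scatter, but no single-point step links the two. Compound 4 `COc1cc(C(=O)O)ccc1Cn1ccc2ccc(NC(=O)CC3CCCC3)cc21` differs from compound 1 in one place: cyclopentylmethyl in place of butoxy on a carbonyl carbon. Within the data shown here, no measured step alters the group on this carbonyl carbon; the only single-point step available concerns a chloro elsewhere and lies within the scatter. With the core of compound 1 unchanged, a 1.3-fold lower number from compound 1 to compound 4 (0.11 log units; within the scatter) is expected to stay within the scatter. Compound 4 is therefore estimated at 120 nM, range 40 nM to 400 nM.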

Compound 4, antagonist equilibrium constant: 20.7 nM
Compound 4: middle estimate off by 5.8-fold (0.76 log units), on the high side; the measured number lies below the stated range.
By their numbers in this assay, from the lowest: compound 2; then compound 4; then compounds 3 and 1 (each within the scatter of the next).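

In this assay, within the data shown here, the group on this carbonyl carbon proves to be a place where a single change moves the number: a 7.5-fold lower number from compound 1 to compound 4 (0.87 log units; beyond the scatter) is the first one-place step to go beyond the scatter, whereas a 1.7-fold lower number from compound 1 to compound 3 (0.22 log units; within the scatter) stays within it. The change takes out butoxy, with its oxygen, and brings in the carbon-only ring of cyclopentylmethyl, and this one step cannot tell those two parts apart. No evidence on hand bears on the cause of the step.

A plain butyl chain or a cyclopentyloxy group on the same carbonyl carbon would separate the two parts. On these data alone, whether chloro on the shared core behaves the same with cyclopentylmethyl in place stays open.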